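From methylsulfanyl to carbamoyl: what number to expect

The compounds below may be only part of what the source reports. "The series", "measured", "known", "first", "only" and "open" are said of these compounds alone.

Among the measured compounds shown here, in a physicochemical assay for solubility, at pH 7.4 (on this read-out higher numbers stand for higher solubility and lower numbers for lower solubility), compound 1 (`Cc1cc(NC(=O)Nc2ccccc2C(C)(C)C)c2ccccc2n1`) gives 100 nM and compound 2 (`CSc1ccccc1NC(=O)Nc1cc(C)nc2ccccc12`) gives 21000 nM as the higher of the two numbers so far. Compound 3 (`Cc1cc(NC(=O)Nc2ccccc2C(N)=O)c2ccccc2n1`) has not yet been measured. It differs from compound 2 by carbamoyl in place of methylsulfanyl on an aromatic carbon, ortho to a large group (carbamoyl in place of methylsulfanyl on an aromatic carbon). For the measured compounds named here, one measured step bears on this change: methylsulfanyl in place of tert-butyl on an aromatic carbon gave a 210-fold higher number from compound 1 to compound 2 (2.32 log units; beyond the scatter) and counts as large. That step shows that a swap of this kind can move the number strongly, but it says nothing about carbamoyl. The expected result in this assay is therefore a small move, within the scatter: an estimated 1.4-fold lower number from compound 2 to compound 3 (0.15 log units; within the scatter) and not a jump of the earlier size. For compound 3 the expected value is 15000 nM within an estimated range from 2000 nM to 80000 nM as a wide span resting on one step.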

Compound 3, solubility: 200 nM
The estimate for compound 3 lay 75-fold (1.88 log units) above the measured number; measured number outside the range, below it.
By their numbers in this assay, from the lowest: compounds 1 and 3 (each within the scatter of the next); then compound 2.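

In this assay, carbamoyl in place of methylsulfanyl gives a 110-fold lower number from compound 2 to compound 3 (2.02 log units; beyond the scatter) on this aromatic carbon, so the high number of compound 2 does not carry over to every other group placed there. Carbamoyl in place of tert-butyl gives a 2.0-fold higher number from compound 1 to compound 3 (0.30 log units; within the scatter) and leaves compound 1 and compound 3 indistinguishable, which makes methylsulfanyl the only one of these three groups that stands apart, with steps beyond the scatter to both others. Nothing available here explains why these groups differ in this way.

The compounds shown leave open whether the high number belongs to methylsulfanyl alone or extends to close relatives such as methoxy or ethylsulfanyl. They also leave open what an amine or a carboxylic acid on the same carbon would give.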